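Removing the chloro from compound 3: what the numbers allow

This account rests on a few compounds, and the source may have more. Where it says the series, first, only, none or still open, it means among the compounds named here.

Compound 3 `Cc1cc(OCC2=NCCO2)ccc1Cl` stands second highest of the three numbers measured in a functional assay on the whole organism for inhibition, with Rattus norvegicus as the target, read by paw edema, with a stated time of 30 min, at a dose of 80 mg/kg by the oral route; on this read-out higher numbers stand for a stronger effect at the one dose given and lower numbers for a weaker effect. In this assay compound 3 gives 77.1%. Compound 1 `Clc1ccc(OCC2=NCCO2)cc1` gives 94.1% in this assay, and compound 2 `Brc1ccccc1OCC1=NCCO1` gives 62.8%. Among the measured compounds shown here, the one measured step between compounds differing in a single place is a number 17 percentage points lower from compound 1 to compound 3 (beyond the scatter), and that step concerns a methyl, not the chloro.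

Compound 4 `Cc1cccc(OCC2=NCCO2)c1` differs from compound 3 in one place: hydrogen in place of chloro on an aromatic carbon. For the measured compounds named here, no measured pair shows the loss of a chloro, so the direction and size of this step can only be guessed from the fact that all three measured compounds carry a halogen and the unsubstituted core is unknown. He therefore expects a downward step in this assay, likely beyond the scatter, since the change removes the one group that compound 1, at 94.1%, compound 2 and compound 3 share. For compound 4 the estimate is 60% with a range from 40% to 80%, a step of a number 17.1 percentage points lower from compound 3 to compound 4 (beyond the scatter) that is expected, not measured.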

Compound 4, a percentage reported as inhibition, in the whole organism at one dose (the size of the read-out at that dose, not a potency): 64.1%
Beside the measured number, compound 4's estimate is 4.1 percentage points below it, within the range that was stated.
By their numbers in this assay, from the lowest: compounds 2 and 4 (each within the scatter of the next); then compound 3; then compound 1.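

Hydrogen in place of chloro gives a number 13 percentage points lower from compound 3 to compound 4 (beyond the scatter) in this assay and is the only step shown that removes a halogen. The step therefore gives the chloro, ortho to a methyl group and para to a group of 7 heavy atoms, a measured part in the read-out, and its direction no longer rests on what the halogen-bearing compounds have in common. The compounds shown offer no evidence on why the read-out falls with this change.

On these data alone, whether other groups at this place, such as a bromo, a methoxy or an amine, would keep the read-out near that of compound 3 remains open. So does the size of the same chloro loss in the absence of the methyl, on the core of compound 1.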